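The source may hold more compounds than are shown below. What is called first, only, known or untested is meant among the compounds shown, and "the series" means these compounds.

Measured compounds and their values in the cytotoxicity test:

Compound 1, `O=C(CSc1c[nH]c2ccccc12)NCc1ccc(C(F)(F)F)cc1`: > 100000 nM
Compound 2, `Cn1cc(SCC(=O)NCc2ccc(C(F)(F)F)cc2)c2ccccc21`: > 100000 nM
Compound 3, `Cn1cc(SCC(=O)N(Cc2ccccc2)Cc2ccccc2)c2ccccc21`: 91200 nM

All three compounds were tested in an ADME assay on HEK-293T cells (Homo sapiens) for cytotoxicity, read by CCK-8 assay, with a stated time of 24 h; on this read-out higher numbers stand for lower toxicity in this test and lower numbers for higher toxicity in this test. Compound 1 gives > 100000 nM, which is a limit of the test and not a number. Compound 2 likewise gives > 100000 nM, again a limit rather than a number. Among the measured compounds shown here, compound 3 is the only one with an actual number, giving 91200 nM in this assay.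

Compounds 2 and 1 differ in one place: hydrogen in place of methyl on an aromatic nitrogen. The step this change made, a step that the two limits leave unreadable from compound 2 to compound 1, cannot be read in size because both values sit at the limit of > 100000 nM in this assay, at which 2 of the 3 values shown sit. Compound 3 carries a different core from compound 2; that difference between the two cores is not broken down here.

The unmeasured compound 4, `O=C(CSc1c[nH]c2ccccc12)N(Cc1ccccc1)Cc1ccccc1`, relates to compound 3 the way compound 1 relates to compound 2: hydrogen in place of methyl on an aromatic nitrogen. The place is described in the same words both times, so this is the same change. Its size is expected to be small, estimated as a 1.1-fold higher number from compound 3 to compound 4 (0.04 log units; within the scatter), because compound 3 already gives 91200 nM. For the measured compounds named here, that number sits close to the limit of > 100000 nM in this assay, at which 2 of the 3 values shown sit, and the one measured example of this change left both partners at that limit. Compound 4 is therefore expected to give about 100000 nM, estimated between 50000 nM and 200000 nM, with a fair chance that this assay reports only a limit.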

Compound 4, half-maximal cytotoxic concentration: > 100000 nM
Compound 4 gave a limit, no number (the forecaster's own chance of this, stated with the estimate: 60%); the middle value lies on the limit itself.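

In this assay, hydrogen in place of methyl on an aromatic nitrogen, carried over to the core of compound 3, gave an at least 1.0-fold higher number from compound 3 to compound 4 (0.04 log units; that floor lies within the scatter). Compound 4 gives > 100000 nM, which is a limit of the test and not a number. This result shows only that nothing in the test speaks against carrying the change from one core to the other, but it does not show how large the change really is on the core of compound 3 or that it has the same size on both cores, because the step on the other core cannot be read and the values crowd at one ceiling: the limit of > 100000 nM in this assay, at which 3 of the 4 values shown sit.

The compounds shown leave open what other groups on that same aromatic nitrogen would do in this assay, for example ethyl, a longer chain, or a chain ending in an amine or a carboxylic acid. As far as these compounds go, they also leave open how far compounds 1, 2 and 4 actually lie past the limit, so the real distance between any of them and compound 3 remains unknown.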